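The source may hold more compounds than are shown below. What is called first, only, known or untested is meant among the compounds shown, and "the series" means these compounds.

Measured compounds in an assay on cell membranes for displacement of a labelled ligand from corticotropin-releasing factor receptor 1 (Rattus norvegicus); on this read-out higher numbers stand for weaker inhibition and lower numbers for stronger inhibition:
compound 1, `CCN(CC)c1nc(C)nc2c(-c3c(C)cc(OC)cc3OC)c(C)nn12`, 1.2 nM
compound 2, `COc1cc(C)c(-c2c(C)nn3c(NC4CCC4)nc(C)nc23)c(OC)c1`, 17.4 nM
compound 3, `CCN(CCC#N)c1nc(C)nc2c(-c3c(C)cc(OC)cc3OC)c(C)nn12`, 2.48 nM

Compound 3 stands second highest of the three numbers in this assay. Its nearest neighbour is compound 1, with the step of a 2.1-fold higher number from compound 1 to compound 3 (0.32 log units; beyond the scatter); its furthest is compound 2, with the step of a 7.0-fold lower number from compound 2 to compound 3 (0.85 log units; beyond the scatter).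

Compound 4 is `CCCN(CCC)c1nc(C)nc2c(-c3c(C)cc(OC)cc3OC)c(C)nn12`. The change from compound 3 is dipropylamino in place of (2-cyanoethyl)(ethyl)amino on an aromatic carbon.

Within the data shown here, two measured steps bear on this. The step of a 2.1-fold higher number from compound 1 to compound 3 (0.32 log units; beyond the scatter) shows that introducing the cyano group on the chain brought a modest rise; compound 4 removes that group again, so a reversal of roughly that size is expected. The step of a 15-fold higher number from compound 1 to compound 2 (1.16 log units; beyond the scatter) shows that exchanging the whole amino group for cyclobutylamino brought a large rise; compound 4 keeps two open chains on the nitrogen, as in compound 1, so no such large movement is expected. For compound 4 a modest step lower is therefore expected, a 1.7-fold lower number from compound 3 to compound 4 (0.22 log units; within the scatter), landing near compound 1. The estimated value for compound 4 is 1.5 nM, within the range 0.5 nM to 5 nM.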

Compound 4, half-maximal inhibitory concentration: 3.72 nM
The estimate for compound 4 lay 2.5-fold (0.39 log units) below the measured number; low and high end bracket the measured number.
By their numbers in this assay, from the lowest: compound 1; then compounds 3 and 4 (each within the scatter of the next); then compound 2.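

In this assay, swapping the (2-cyanoethyl)(ethyl)amino group for dipropylamino on this aromatic carbon gives no change that can be read beyond the scatter (a 1.5-fold higher number from compound 3 to compound 4 (0.18 log units; within the scatter)), so the nitrile-bearing chain and a plain propyl chain are not separated here. Among the open-chain groups, the length of the two chains does register, though only modestly (a 3.1-fold higher number from compound 1 to compound 4 (0.49 log units; beyond the scatter)), while dipropylamino keeps a modest margin over cyclobutylamino (a 4.7-fold lower number from compound 2 to compound 4 (0.67 log units; beyond the scatter)). No supporting data on the series explains any of these differences.

Open, as far as these compounds go, is how the number responds to dibutylamino, which would extend the diethylamino-to-dipropylamino comparison by a further step. Also open, from the compounds shown here alone, is whether an ether such as (2-methoxyethyl)(ethyl)amino would behave like the nitrile-bearing chain.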